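Thiophen-2-yl in Place of 2-Chlorophenyl: An Unreadable Step

The compounds below may be only part of what the source reports. "The series", "measured", "known", "first", "only" and "open" are said of these compounds alone.

Compound 1 `CC1=CC[C@H](C(C)(C)NC(=S)N/N=C/c2ccc(O)cc2)CC1` gives > 100000 nM in a functional assay on 786-0 cells (Homo sapiens) for inhibition, read by sulforhodamine B assay, with a stated time of 48 h (a higher number here means a weaker inhibitor of growth, a lower number a stronger inhibitor of growth), a limit of the assay.
Compound 2 `CC1=CC[C@H](C(C)(C)NC(=S)N/N=C/c2ccccc2Cl)CC1` gives > 100000 nM in this assay, also a limit of the assay.

Among the compounds with values here, compound 2 stands at the same limit as the only other measured value (the limit of > 100000 nM in this assay, at which 2 of the 2 values shown sit). The step that the two limits leave unreadable from compound 1 to compound 2 has limits at both ends and yields no size and no direction. Compound 3 `CC1=CC[C@H](C(C)(C)NC(=S)N/N=C/c2cccs2)CC1` differs from compound 2 by thiophen-2-yl in place of 2-chlorophenyl on a carbon with a double bond to nitrogen. Within the data shown here, the one measured step bears on this change only in the sense that both ends sit at the limit (the limit of > 100000 nM in this assay, at which 2 of the 2 values shown sit), so no change in this assay beyond the scatter can be read from it in either direction. Compound 3 is therefore expected to remain near that limit, with an estimated value of 100000 nM and a range from 30000 nM to 300000 nM. The expected step is a number no higher from compound 2 to compound 3 (the limit leaves the size open), meaning no shift that the measurements could reveal.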

Compound 3, concentration for total growth inhibition: 26700 nM
The estimate for compound 3 lay 3.7-fold (0.57 log units) above the measured number; the measured number lies below the stated range.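

At the carbon with a double bond to nitrogen, the choice of group can now be seen to move the read-out in this assay: thiophen-2-yl in place of 2-chlorophenyl gives an at least 3.7-fold lower number from compound 2 to compound 3 (0.57 log units; beyond the scatter), and thiophen-2-yl in place of 4-hydroxyphenyl gives an at least 3.7-fold lower number from compound 1 to compound 3 (0.57 log units; beyond the scatter). Both steps start from a limit of the assay and give only a minimum size, while the step between compound 1 and compound 2 cannot be read. Compound 3 is the only one of the three with a value off that limit: the limit of > 100000 nM in this assay, at which 2 of the 3 values shown sit.

From the compounds shown here alone, whether furan-2-yl, with oxygen in place of the ring sulfur, would give a number like that of compound 3 remains open. So does the effect on the read-out of an amine or a carboxylic acid carried on the thiophen-2-yl ring.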